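A few compounds are considered here, and "the series" means these few. Any claim that something is new, unique, unknown or untested is made for them only; others in the source may bear on it.

Measured compounds:
- Compound 1 `FC(F)(F)c1ccccc1-c1ccc2[nH]c(C3=NCC4(CCCCC4)O3)nc2c1`: 40%
- Compound 2 `FC(F)(F)c1ccccc1-c1ccc2[nH]c(C3=NOC4(CCCCC4)C3)nc2c1`: 71%
- Compound 3 `Fc1ccccc1-c1ccc2[nH]c(C3=NOC4(CCCCC4)C3)nc2c1`: 47%

In an ADME assay on microsomes from liver (Canis lupus familiaris) for metabolic stability, with a stated time of 10 min (a higher number here means that more of the compound is left, a lower number that less of the compound is left), compound 3 gives 47% and compound 1 gives 40%, two values within the scatter of each other. Compound 2 gives 71%, clearly more than compound 3.

The next compound, compound 4 `Fc1cccc(OC(F)(F)F)c1-c1ccc2[nH]c(C3=NOC4(CCCCC4)C3)nc2c1`, keeps the fluoro group of compound 3 and changes it in one place: trifluoromethoxy in place of hydrogen on an aromatic carbon. In words, this is trifluoromethoxy in place of hydrogen on an aromatic carbon, ortho to a large group and meta to a fluoro group.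

For the measured compounds named here, only one measured step bears on this: a number 24 percentage points lower from compound 2 to compound 3 (beyond the scatter), with fluoro in place of trifluoromethyl. That change is not the same as the new one, so it is only a weak guide, but it points upward for a compound that regains a trifluorinated group. A modest rise is therefore expected, a number 13 percentage points higher from compound 3 to compound 4 (beyond the scatter). For compound 4 the estimate is 60%, with an expected range from 42% to 78%.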

Compound 4, percent of the compound remaining: 73%
The estimate for compound 4 lay 13 percentage points below the measured number, and the stated range covers the measured number.
By their numbers in this assay, from the lowest: compounds 1 and 3 (each within the scatter of the next); then compounds 2 and 4 (each within the scatter of the next).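

In this assay, trifluoromethoxy in place of hydrogen gives a number 26 percentage points higher from compound 3 to compound 4 (beyond the scatter), so a single added group can move this read-out by more than the usual scatter. For the compounds shown here, the carbon involved, ortho to a large group and meta to a fluoro group, carries only hydrogen in compounds 1, 2 and 3, which makes this the first sign that a change at this place matters and that the fluoro group of compound 3 can stay while the number still rises. Nothing measured here explains the rise.

From the compounds shown here alone, what a methoxy group, a chlorine atom or an amine at this same carbon would give remains open. Going by these compounds, it is also open whether trifluoromethoxy would raise the number in the same way on compound 2, which has trifluoromethyl where compound 3 has fluoro.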